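Swapping the Carbonyl Substituent of Compound 3

A few compounds are considered here, and "the series" means these few. Any claim that something is new, unique, unknown or untested is made for them only; others in the source may bear on it.

Compound 3 `Cc1nc(S(C)(=O)=O)ccc1Oc1ncnc(OC2CCN(C(=O)SC3CCC3)CC2)c1F` reaches 81% in a functional assay on isolated protein for inhibition of Glucose-dependent insulinotropic receptor (Rattus norvegicus), read by HTRF and cAMP accumulation (a lower number here means a smaller maximal response, a higher number a larger maximal response), the lowest of the three numbers shown, though its steps to both neighbours lie within the scatter: a number 2 percentage points lower from compound 1 to compound 3 (within the scatter) from compound 1 `CCC1(OC(=O)N2CCC(Oc3ncnc(Oc4ccc(S(C)(=O)=O)nc4C)c3F)CC2)CC1`, which gives 83%, and a number 3 percentage points lower from compound 2 to compound 3 (within the scatter) from compound 2 `Cc1nc(S(C)(=O)=O)ccc1Oc1ncnc(OC2CCN(C(=O)OC3(C(F)(F)F)COC3)CC2)c1F`, which gives 84%. The remaining step is likewise flat: a number 1 percentage points higher from compound 1 to compound 2 (within the scatter). Compound 4 `Cc1nc(S(C)(=O)=O)ccc1Oc1ncnc(OC2CCN(C(=O)C(C)(F)F)CC2)c1F` carries a new group at the same position: 1,1-difluoroethyl in place of cyclobutylsulfanyl on a carbonyl carbon. Every measured step changed the group on this carbonyl carbon without moving beyond the scatter, so a similar outcome is expected here, namely a number 1 percentage points higher from compound 3 to compound 4 (within the scatter). Compound 4 is therefore estimated at 82%, within 72% to 92%.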

Compound 4, largest response reached (reported as efficacy), in percent of the reference or control that the assay uses: 87%
Compound 4: middle estimate off by 5 percentage points, on the low side; low and high end bracket the measured number.
By their numbers in this assay, from the lowest: compounds 3, 1, 2 and 4 (each within the scatter of the next).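

With 1,1-difluoroethyl, the carbonyl carbon carries a group joined through carbon rather than through oxygen or sulfur, and one with no ring, yet in this assay the steps stay small: a number 6 percentage points higher from compound 3 to compound 4 (within the scatter) and a number 3 percentage points higher from compound 2 to compound 4 (within the scatter) and a number 4 percentage points higher from compound 1 to compound 4 (within the scatter) all hold. Across these four compounds, then, neither the joining atom nor the ring moves the maximal response beyond the scatter. No measurement shown bears on why this position tolerates these changes. Among the compounds shown here, still open is whether a dimethylamino group or a carboxylic acid on this carbonyl carbon would fit the same flat picture or give the first step beyond the scatter.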